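A ring exchange on a shared core

The source may hold more compounds than are shown below. What is called first, only, known or untested is meant among the compounds shown, and "the series" means these compounds.

In a physicochemical assay for solubility, in phosphate buffer, measured as kinetic solubility (on this read-out lower numbers stand for lower solubility and higher numbers for higher solubility), compound 2 `CC(C)C(c1ccc(-c2ccc3cccc(F)c3c2)[nH]c1=O)C1SC(=O)NC1=O` gives 20100 nM. That number lies within the usual scatter of compound 1 `CC(C)C(c1ccc(-c2ccc3cccc(F)c3c2)[nH]c1=O)C1NC(=O)NC1=O`, at 10600 nM, and of compound 3 `O=C1NC(=O)/C(=C/C(c2ccc(-c3ccc4cccc(F)c4c3)[nH]c2=O)C2CC2)O1`, at 30800 nM. Compound 4 `CC(C)C(CC1NC(=O)NC1=O)c1ccc(-c2ccc3cccc(F)c3c2)[nH]c1=O` has not yet been measured. It differs from compound 2 in one place: (2,5-dioxoimidazolidin-4-yl)methyl in place of 2,4-dioxo-1,3-thiazolidin-5-yl on a saturated chain carbon bound to an aromatic carbon and a saturated chain carbon. Going by the values given here, one measured step bears on this change. Compound 1 carries 2,5-dioxoimidazolidin-4-yl on the same saturated chain carbon where compound 2 carries 2,4-dioxo-1,3-thiazolidin-5-yl, and the step is a 1.9-fold higher number from compound 1 to compound 2 (0.28 log units; within the scatter). Read in reverse, that small step points to no change beyond the scatter in this assay. Among the compounds with values here, no measured pair isolates the methyl part of the entering group, so the expectation remains loose. The estimated step is a 1.3-fold lower number from compound 2 to compound 4 (0.13 log units; within the scatter), which is no larger than the scatter. Compound 4 is expected to give about 15000 nM, with an estimated range of 6000 nM to 35000 nM.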

Compound 4, solubility: 12300 nM
Compound 4: middle estimate off by 1.2-fold (0.09 log units), on the high side, and the stated range covers the measured number.
By their numbers in this assay, from the lowest: compounds 1, 4, 2 and 3 (each within the scatter of the next, the first and the last beyond it).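

Compound 4 supplies the comparison that was missing: it keeps the 2,5-dioxoimidazolidin-4-yl of compound 1 and adds only the methyl part of the entering group, and in this assay this change gives a 1.2-fold higher number from compound 1 to compound 4 (0.06 log units; within the scatter) within the scatter. Exchanging the 2,4-dioxo-1,3-thiazolidin-5-yl for the whole (2,5-dioxoimidazolidin-4-yl)methyl gives a 1.6-fold lower number from compound 2 to compound 4 (0.21 log units; within the scatter) and also stays within the scatter. At this saturated chain carbon bound to an aromatic carbon and a saturated chain carbon, neither change can therefore be told apart from the spread of repeated measurements.

Nothing in the available data offers an explanation for these numbers. Still open, on these data alone, is whether a carboxylic acid, an amine or a longer chain carrying the 2,5-dioxoimidazolidin-4-yl at this place would also stay within the scatter.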